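Acetyl in place of chlorobenzoyl, second instance in the series

A few compounds are considered here, and "the series" means these few. Any claim that something is new, unique, unknown or untested is made for them only; others in the source may bear on it.

Measured so far:
- compound 1, `CC(=O)N1c2ccccc2CCC1C(=O)Nc1cc(C(F)(F)F)cc(C(F)(F)F)c1`: in a functional assay on NCI-H23 cells (Homo sapiens) for cytotoxicity, read by sulforhodamine B assay, with a stated time of 72 h (a lower number here means a stronger inhibitor of growth, a higher number a weaker inhibitor of growth), compound 1 gives > 70000 nM, which is a limit of the assay, not a number.
- compound 2, `O=C(Nc1cc(C(F)(F)F)cc(C(F)(F)F)c1)C1CCc2ccccc2N1C(=O)c1ccc(Cl)cc1`: in this assay compound 2 gives 889 nM.
- compound 3, `O=C(Nc1ccccc1C(F)(F)F)C1CCc2ccccc2N1C(=O)c1ccc(Cl)cc1`: in this assay compound 3 gives 307 nM.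

The difference between the cores of compound 2 and compound 3 is not broken down here; their two values show compound 3 with the lower number. Among the compounds with values here, the one counted change, (methyl in place of 4-chlorophenyl on a carbonyl carbon), gives an at least 78-fold higher number from compound 2 to compound 1 (1.89 log units; beyond the scatter), the surviving value being (the limit of > 70000 nM in this assay, at which 1 of the 3 values shown sits).

Compound 4, `CC(=O)N1c2ccccc2CCC1C(=O)Nc1ccccc1C(F)(F)F`, is compound 3 with the same change, (methyl in place of 4-chlorophenyl on a carbonyl carbon), at the same place. From compound 3 to compound 4 a loss like a 130-fold higher number from compound 3 to compound 4 (2.11 log units; beyond the scatter) is expected in this assay, resting on an at least 78-fold higher number from compound 2 to compound 1 (1.89 log units; beyond the scatter). For compound 4 the estimate is 40000 nM, between 10000 nM and 150000 nM, with a real chance that only a limit is reported.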

Compound 4, concentration for 50% growth inhibition: > 80000 nM
Compound 4 ended at the assay's limit; the forecaster's own chance of this, stated with the estimate: 50%; middle value at least 2.0-fold (0.30 log units) from the limit.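

In this assay, putting methyl in place of 4-chlorophenyl on the carbonyl carbon gives an at least 260-fold higher number from compound 3 to compound 4 (2.41 log units; beyond the scatter), so the large loss seen on the first core recurs on the second. For compound 4, > 80000 nM is a limit of the assay, not a number. The direction of the change therefore carries across both cores, but its size cannot be compared between them: the same change on two cores in this assay, an at least 78-fold higher number (1.89 log units; beyond the scatter) from compound 2 to compound 1 and an at least 260-fold higher number (2.41 log units; beyond the scatter) from compound 3 to compound 4; the limit leaves it open whether they differ

Open, on these data alone, is what happens between these two ends of the change, with a plain phenyl, a cyclohexyl or a longer alkyl chain on that carbonyl carbon. Also open, as far as these compounds go, is whether the chlorine itself is needed for the growth inhibition of compound 2 and compound 3.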